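Compound 2 to compound 3: adding 3-chlorobenzyl on oxygen

A few compounds are considered here, and "the series" means these few. Any claim that something is new, unique, unknown or untested is made for them only; others in the source may bear on it.

- In an ADME assay on HepG2 cells (Homo sapiens) for cytotoxicity, read by MTT assay, with a stated time of 48 h (a higher number here means a weaker inhibitor, a lower number a stronger inhibitor), compound 1 `Cc1ccc(Nc2ncnc3ccc(-c4ccc(S(=O)(=O)N5CCOCC5)cc4)cc23)cc1` gives > 15000 nM as a limit
- In this assay compound 2 `O=S(=O)(c1ccc(-c2ccc3ncnc(Nc4ccc(O)c(Cl)c4)c3c2)cc1)N1CCOCC1` gives > 15000 nM as a limit

Compound 2 stands at a limit and not a number, with the limit of > 15000 nM in this assay, at which 2 of the 2 values shown sit, as the whole picture so far. Compound 3 `O=S(=O)(c1ccc(-c2ccc3ncnc(Nc4ccc(OCc5cccc(Cl)c5)c(Cl)c4)c3c2)cc1)N1CCOCC1` turns hydroxy to (3-chlorobenzyl)oxy, with 3-chlorobenzyl in place of hydrogen on an oxygen on an aromatic ring as the counted difference from compound 2. Going by the values given here, the only measured step (a step that the two limits leave unreadable from compound 1 to compound 2) supplies no size to carry over. For compound 3 a modest move toward lower numbers is expected (an at least 1.6-fold lower number from compound 2 to compound 3 (0.22 log units; that floor lies within the scatter)) and nothing firmer. Compound 3 is estimated at 9000 nM within a range of 3000 nM to 25000 nM and may also return only a limit.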

Compound 3, half-maximal inhibitory concentration: > 15000 nM
Compound 3: no number, only a limit; the forecaster's own chance of this, stated with the estimate: 45%; at least 1.6-fold (0.22 log units) between middle value and limit.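

Compound 2 and compound 3 both return only limits in this assay, so the step between them cannot be read. Whether adding 3-chlorobenzyl on the oxygen changes the read-out at all stays open, as do the actual values of all the compounds shown.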